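The source may report more compounds than this note shows. Statements on the series, on what has been measured and on what is new or still open speak of the compounds shown alone.

Measured so far in an ADME assay on A549 cells (Homo sapiens) for cytotoxicity, read by resazurin assay, with a stated time of 48 h; a lower number here means that less compound is tolerated, a higher number that more compound is tolerated:

Compound 1, `O=C(Nc1ccc(NCc2ccc(Cl)cc2)cc1Cl)c1cc(Cl)ccc1O`: 59700 nM
Compound 2, `O=C(Nc1ccc(NCc2ccc(C(F)(F)F)cc2)cc1Cl)c1cc(Cl)ccc1O`: 62700 nM
Compound 3, `O=C(Nc1ccc(NCc2cc(Cl)cc(Cl)c2)cc1Cl)c1cc(Cl)ccc1O`: 13300 nM

Compound 4, `O=C(Nc1ccc(NCc2cc(Cl)cc(C(F)(F)F)c2)cc1Cl)c1cc(Cl)ccc1O`, has not yet been measured. It differs from compound 3 by trifluoromethyl in place of chloro on an aromatic carbon. A change of the same kind has been measured once before, from compound 1 to compound 2, where (trifluoromethyl in place of chloro on an aromatic carbon); there the group sits para to a large group, whereas in compound 4 it sits meta to a chloro group and meta to a large group. That earlier step gave a 1.1-fold higher number from compound 1 to compound 2 (0.02 log units; within the scatter). The two cores differ as well: 3,5-dichlorophenyl in place of 4-chlorophenyl on a saturated chain carbon bound to a nitrogen on an aromatic ring. Resting on the earlier step, the change from compound 3 to compound 4 is expected to give about a 1.1-fold higher number from compound 3 to compound 4 (0.05 log units; within the scatter) in this assay. Compound 4 is therefore estimated at 15000 nM, with a likely range from 7000 nM to 32000 nM.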

Compound 4, half-maximal cytotoxic concentration: 30900 nM
The estimate for compound 4 lay 2.1-fold (0.31 log units) below the measured number, and the stated range covers the measured number.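

In this assay, trifluoromethyl in place of chloro gives a 2.3-fold higher number from compound 3 to compound 4 (0.37 log units; beyond the scatter), a modest step when read alone. Set beside the earlier step, the change carries from one core to the other with no difference that stands out from the usual scatter: the same change on two cores in this assay, a 1.1-fold higher number (0.02 log units; within the scatter) from compound 1 to compound 2 and a 2.3-fold higher number (0.37 log units; beyond the scatter) from compound 3 to compound 4, 2.2-fold (0.34 log units) apart, within the scatter of two such steps. Two pairs are too few to show that this would hold on a further core, and in compound 4 the group sits meta to a chloro group and meta to a large group, so the effects of core and place are not told apart.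

The compounds shown leave open how a nitrile or a methoxy group in that same place would compare.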